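A Side-Group Swap on Compound 3

The compounds below may be only part of what the source reports. "The series", "measured", "known", "first", "only" and "open" are said of these compounds alone.

In a functional assay on HCT-116 cells (Homo sapiens) for antiproliferative activity, read by sulforhodamine B assay (a lower number here means a stronger inhibitor, a higher number a weaker inhibitor), compound 3 (`CN1CCN(c2ccc(N/C=C3\C(=O)NC(=O)c4ccc(-c5ccsc5)cc43)cc2)CC1`) gives 1400 nM and compound 2 (`CN1CCN(c2ccc(N/C=C3\C(=O)NC(=O)c4ccc(-c5ccoc5)cc43)cc2)CC1`) gives 1200 nM while compound 1 (`O=C1NC(=O)c2ccc(-n3cccc3)cc2/C1=C/Nc1ccc(CN2CCCCC2)cc1`) gives 2700 nM here, which places compound 3 within the scatter of both. Compound 4 (`O=C1NC(=O)c2ccc(-c3ccsc3)cc2/C1=C/Nc1ccc(CN2CCCCC2)cc1`) differs from compound 3 in one group ((piperidin-1-yl)methyl in place of 4-methylpiperazin-1-yl on an aromatic carbon), with (piperidin-1-yl)methyl in place of 4-methylpiperazin-1-yl on an aromatic carbon. For the measured compounds named here, no measured step covers this swap. Going by the values given here, the one measured step (a 1.2-fold higher number from compound 2 to compound 3 (0.07 log units; within the scatter)) concerns another group. Compound 1 already carries (piperidin-1-yl)methyl, and its 2700 nM lies within the scatter of compound 3, so a step within the scatter, leaning towards a higher number, is expected. In this assay the expected move is a 1.3-fold higher number from compound 3 to compound 4 (0.11 log units; within the scatter) and no more. Compound 4 is expected at 1800 nM (range 800 nM to 4000 nM).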

Compound 4, half-maximal inhibitory concentration: 1000 nM
The estimate for compound 4 lay 1.8-fold (0.26 log units) above the measured number; measured number inside the range.
By their numbers in this assay, from the lowest: compounds 4, 2, 3 and 1 (each within the scatter of the next, the first and the last beyond it).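

In this assay, (piperidin-1-yl)methyl in place of 4-methylpiperazin-1-yl on an aromatic carbon gives a 1.4-fold lower number from compound 3 to compound 4 (0.15 log units; within the scatter), so this position takes either group without a clear change. For the compounds shown here, the thiophen-3-yl in place of 1H-pyrrol-1-yl step gives a 2.7-fold lower number from compound 1 to compound 4 (0.43 log units; beyond the scatter), the first step here beyond the scatter, and it lies at the other site of variation. Nothing available explains either step.

From the compounds shown here alone, whether a morpholine ring or a carboxylic acid would also be tolerated at this position stays open. So does whether the thiophen-3-yl step would repeat with 4-methylpiperazin-1-yl present.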